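This account rests on a few compounds, and the source may have more. Where it says the series, first, only, none or still open, it means among the compounds named here.

Of the compounds shown here, three sharing one core have been tested in an ADME assay on L6 cells (Rattus norvegicus) for cytotoxicity, read by resazurin assay, with a stated time of 72 h; a higher number here means a weaker inhibitor, a lower number a stronger inhibitor. Compound 1 `OC(c1ccc(Cl)cc1)(c1cccnc1)c1ccccc1F` gives > 100000 nM, which is a limit of the assay and not a number. Compound 2 `Cc1ccccc1C(O)(c1ccc(Cl)cc1)c1cccnc1` gives a measured number, 82000 nM. Compound 3 `OC(c1ccc(Cl)cc1)(c1cccnc1)c1nccs1` gives > 100000 nM, again a limit and not a number. Compound 3 therefore stands at the limit of > 100000 nM in this assay, at which 2 of the 3 values shown sit.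

Compound 4 `OC(c1ccc(Cl)cc1)(c1cccnc1)c1cncs1` has the same atoms as compound 3, joined differently: 1,3-thiazol-5-yl in place of 1,3-thiazol-2-yl on a saturated chain carbon bound to two aromatic carbons and an oxygen on a saturated carbon. The change is 1,3-thiazol-5-yl in place of 1,3-thiazol-2-yl.

Among the measured compounds shown here, no measured step swaps one thiazolyl group for another, so the nearest guides are changes at the same carbon. One is an at least 1.2-fold higher number from compound 2 to compound 3 (0.08 log units; that floor lies within the scatter), and the other is a step that the two limits leave unreadable from compound 1 to compound 3. The methyl-for-fluoro change elsewhere gave an at least 1.2-fold lower number from compound 1 to compound 2 (0.08 log units; that floor lies within the scatter). None of these shows a step beyond the scatter, so none beyond the scatter is expected here either, and another limit may well be reported.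

The expected step in this assay is an at least 1.1-fold lower number from compound 3 to compound 4 (0.04 log units; that floor lies within the scatter). Compound 4 is estimated at 90000 nM, with an expected range from 40000 nM to 150000 nM.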

Compound 4, half-maximal inhibitory concentration: > 100000 nM
Compound 4: only a limit was reported; the forecaster's own chance of this, stated with the estimate: 65%; middle value at least 1.1-fold (0.04 log units) away from the limit.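

Swapping 1,3-thiazol-2-yl for 1,3-thiazol-5-yl leaves compound 4 at a limit of this assay, not at a number, so neither thiazolyl group at this carbon has yet given a readable value. The steps from compound 3 and from compound 1 to compound 4 cannot be read, as both ends of each are limits. The only readable step is an at least 1.2-fold higher number from compound 2 to compound 4 (0.08 log units; that floor lies within the scatter), and the set now gathers at one end of the assay: the limit of > 100000 nM in this assay, at which 3 of the 4 values shown sit.

From the compounds shown here alone, how far apart compound 1, compound 3 and compound 4 truly lie remains unknown. Also open, going by these compounds, is whether an amine or a carboxylic acid in place of the thiazolyl group on this saturated chain carbon would give a readable number.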